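The source may hold more compounds than are shown below. What is called first, only, known or untested is meant among the compounds shown, and "the series" means these compounds.

Of the compounds shown here, two have been measured so far in a functional assay on MV4-11 cells (Homo sapiens) for antiproliferative activity, read by CCK-8 assay, with a stated time of 72 h; on this read-out lower numbers stand for stronger inhibition and higher numbers for weaker inhibition. Compound 1 (`Cn1cc(-c2ccccc2F)c2cc(C(=O)NCc3ccc(C(=O)Nc4ccccc4N)cc3)[nH]c2c1=O`) gives 230 nM, the lower of the two numbers, while compound 2 (`O=C(CCCCCCC(=O)Nc1cnc(N(c2ccccc2)c2ccccc2)nc1)NO`) gives 890 nM, a gap beyond the scatter. Compound 3 (`Cc1ccccc1-c1cn(C)c(=O)c2[nH]c(C(=O)NCc3ccc(C(=O)Nc4ccccc4N)cc3)cc12`) keeps the core of compound 1 and alters a single place, with 2-fluorophenyl becoming 2-methylphenyl: methyl in place of fluoro on an aromatic carbon. This is methyl in place of fluoro on an aromatic carbon. Within the data shown here, no measured pair shows what this swap does, and compound 2 is too different in structure to serve as a guide. The expectation in this assay is therefore a small step towards a slightly higher number, with none beyond the scatter. The estimate amounts to a step of a 1.3-fold higher number from compound 1 to compound 3 (0.12 log units; within the scatter), which is expected to stay within the scatter. Compound 3 is estimated at 300 nM, with an expected range of 120 nM to 750 nM.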

Compound 3, half-maximal inhibitory concentration: 310 nM
For compound 3 the middle estimate is 1.0-fold (0.01 log units) below the measured one; the measured number falls inside the stated range.
By their numbers in this assay, from the lowest: compounds 1 and 3 (each within the scatter of the next); then compound 2.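

In this assay the swap of fluoro for methyl on an aromatic carbon ortho to a large group gives a 1.3-fold higher number from compound 1 to compound 3 (0.13 log units; within the scatter) and so provides the first step read at this position. Compound 1 and compound 3 cannot be told apart on this read-out, so at this place 2-fluorophenyl and 2-methylphenyl read alike, with one heavy atom exchanged for another and no hydrogen-bond donor or acceptor involved. No measurement at hand offers an explanation for this result.

The compounds shown leave open whether this position stays as undemanding with an amine, a carboxylic acid or a methoxy group in place of fluoro or methyl. They also leave open whether the same swap would read alike elsewhere on that ring.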